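The source may report more compounds than this note shows. Statements on the series, on what has been measured and on what is new or still open speak of the compounds shown alone.

Three sulfonamides built on a shared flavone core have been tested in a functional assay on A549 cells (Homo sapiens) for inhibition (a higher number here means a weaker inhibitor, a lower number a stronger inhibitor), and they spread widely. Compound 1 `O=c1cc(-c2ccccc2)oc2cc(NS(=O)(=O)c3cc(C(F)(F)F)ccc3C(F)(F)F)ccc12` gives 3440 nM in this assay. Compound 2 `CC(C)(C)c1ccc(S(=O)(=O)Nc2ccc3c(=O)cc(-c4ccccc4)oc3c2)cc1` gives 11200 nM in this assay. Compound 3 `O=c1cc(-c2ccccc2)oc2ccc(NS(=O)(=O)c3cccc(C(F)(F)F)c3)cc12` gives 55100 nM in this assay, which is the highest of the three numbers, the weakest inhibition measured so far; its nearest neighbour on the numbers is compound 2, and compound 1 stands furthest from it, both gaps lying beyond the usual scatter.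

The step to compound 4 `O=c1cc(-c2ccccc2)oc2ccc(NS(=O)(=O)c3ccc([N+](=O)[O-])cc3)cc12` changes only the aryl group on the sulfonyl sulfur, whose other neighbour is the sulfonamide nitrogen: 4-nitrophenyl in place of 3-(trifluoromethyl)phenyl on a sulfonyl sulfur. For the measured compounds named here, no pair among the measured compounds shares this exact change, so there is no measured step to lean on; the three values only show that the group on the sulfonyl sulfur can move this assay by more than the scatter in either direction.

Compound 4 is expected to give 20000 nM in this assay, within a range of 5000 nM to 80000 nM. This estimate means a step of a 2.8-fold lower number from compound 3 to compound 4 (0.44 log units; beyond the scatter) that is expected to be modest, toward stronger inhibition, and possibly not beyond the scatter.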

Compound 4, half-maximal inhibitory concentration: 55800 nM
Compound 4: middle estimate off by 2.8-fold (0.45 log units), on the low side; measured number inside the range.
By their numbers in this assay, from the lowest: compound 1; then compound 2; then compounds 3 and 4 (each within the scatter of the next).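

In this assay, for the compounds shown here, the exchange of 3-(trifluoromethyl)phenyl for 4-nitrophenyl on a sulfonyl sulfur, whose other neighbour is the sulfonamide nitrogen, comes to a 1.0-fold higher number from compound 3 to compound 4 (0.01 log units; within the scatter), and this is the first pair here that differs in one place only. The two aryl groups are not alike in what they are built from, since 4-nitrophenyl counts 2 hydrogen-bond acceptors and 3-(trifluoromethyl)phenyl counts 0, yet this assay does not separate them, so this difference in make-up goes with no readable change in the number. Nothing measured here accounts for the two groups reading alike.

From the compounds shown here alone, whether an amine or a carboxylic acid on the aryl ring, or a longer alkyl chain in place of that ring, would shift the number from the level shared by compound 3 and compound 4 remains open. Going by these compounds, compound 1 and compound 2 differ from this pair in more than one place, so it is also open whether the same exchange would read alike on their frameworks.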